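This account rests on a few compounds, and the source may have more. Where it says the series, first, only, none or still open, it means among the compounds named here.

Compound 1 `CCCN(CCC)c1cc(C)nc2c(-c3ncc(N(CC)CC)cc3C)c(C)nn12` gives 13 nM in an assay on isolated protein for binding affinity to corticotropin-releasing factor receptor 1 (Homo sapiens); a higher number here means a weaker inhibitor, a lower number a stronger inhibitor; compound 2 `CCCN(CCC)c1cc(C)nc2c(-c3ncc(F)cc3C)c(C)nn12` gives 19 nM; compound 3 `CCCN(CCC)c1cc(C)nc2c(-c3ncc(O)cc3C)c(C)nn12` gives 530 nM.

Compound 3 has the highest number of the three in this assay: a 41-fold higher number from compound 1 to compound 3 (1.61 log units; beyond the scatter) and a 28-fold higher number from compound 2 to compound 3 (1.45 log units; beyond the scatter), both beyond the scatter, whereas a 1.5-fold higher number from compound 1 to compound 2 (0.16 log units; within the scatter) stays within it.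

Compound 4 `CCCN(CCC)c1cc(C)nc2c(-c3ncccc3C)c(C)nn12` carries the change (hydrogen in place of hydroxy on an aromatic carbon). Both measured steps that put the hydroxy in place, from compound 1 and from compound 2, brought a large rise in the number in this assay. Taking it away again is expected to undo that rise, so the expected step of an 18-fold lower number from compound 3 to compound 4 (1.25 log units; beyond the scatter) is a large fall in this assay. For compound 4 the estimated value in this assay is 30 nM, within a range of 10 nM to 100 nM.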

Compound 4, inhibition constant: 110 nM
Compound 4: middle estimate off by 3.7-fold (0.56 log units), on the low side, outside the stated range (above it).
By their numbers in this assay, from the lowest: compounds 1 and 2 (each within the scatter of the next); then compound 4; then compound 3.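

In this assay, hydrogen at this position does not match the best compounds: a 4.8-fold lower number from compound 3 to compound 4 (0.68 log units; beyond the scatter) recovers only part of the loss seen with hydroxy, while a 5.8-fold higher number from compound 2 to compound 4 (0.76 log units; beyond the scatter) and an 8.5-fold higher number from compound 1 to compound 4 (0.93 log units; beyond the scatter) show that fluoro and diethylamino both give lower numbers than hydrogen. The position therefore responds in both directions, with hydroxy giving a higher number than hydrogen and the other two groups giving lower numbers. Nothing available explains this order.

As far as these compounds go, it remains open whether methoxy, an amine or a carboxylic acid here would track fluoro and diethylamino or hydroxy. From the compounds shown here alone, it also remains open whether dimethylamino would match diethylamino.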